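The source may report more compounds than this note shows. Statements on the series, on what has been measured and on what is new or still open speak of the compounds shown alone.

Measured in an ADME assay on BJ cells (Homo sapiens) for cytotoxicity, with a stated time of 72 h; on this read-out lower numbers stand for an effect already at smaller amounts and higher numbers for an effect only at larger amounts of compound:
compound 1 `C=C[C@@](C)(/C=C/c1ccc(OC)cc1)CCC=C(C)C`: > 36600 nM (a limit)
compound 2 `C=C[C@@](C)(/C=C/c1ccc(O)cc1)CC/C=C(\C)CO`: > 36600 nM (a limit)
compound 3 `C=C[C@@](C)(/C=C/c1ccc(O)cc1)CC/C=C(\C)C(=O)OCC`: > 36600 nM (a limit)

Compound 1 gives only a limit, > 36600 nM. The same holds across the whole set, (the limit of > 36600 nM in this assay, at which 3 of the 3 values shown sit).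

Compound 4 `C=C[C@@](C)(/C=C/c1ccc(Nc2ccccc2)cc1)CCC=C(C)C` carries anilino in place of methoxy on an aromatic carbon of the core of compound 1: anilino in place of methoxy on an aromatic carbon. For the measured compounds named here, the one measured step, a step that the two limits leave unreadable from compound 2 to compound 3, lies in the chain and not at that aromatic carbon, so it offers no size to carry over. In this assay no step beyond the scatter is therefore expected. The expected step is an at least 1.2-fold lower number from compound 1 to compound 4 (0.08 log units; that floor lies within the scatter). For compound 4 the estimated value is 30000 nM, within an expected range of 10000 nM to 60000 nM.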

Compound 4, half-maximal effective concentration: > 36600 nM
Compound 4: a limit, no number (the forecaster's own chance of this, stated with the estimate: 65%); at least 1.2-fold (0.08 log units) between middle value and limit.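

Compound 1 and compound 4 both give only a limit, so no step can be read between them. The compounds shown leave open whether any change among them shifts the read-out at all, with every value resting on one limit: the limit of > 36600 nM in this assay, at which 4 of the 4 values shown sit.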